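A few compounds are considered here, and "the series" means these few. Any claim that something is new, unique, unknown or untested is made for them only; others in the source may bear on it.

Compound 1 `CC1=C(C(=O)OC(C)(C)C)C(c2ccsc2)NC(=O)N1`: 15%
Compound 2 `CCCC(=O)C1=C(C)NC(=O)NC1c1ccsc1`: 6%
Compound 3 `CC1=C(C(N)=O)C(c2ccsc2)NC(=O)N1`: 2%

These three compounds share one core and differ only in the group attached to a carbonyl carbon, and all were tested in an assay on membranes from CHO cells for displacement of a labelled ligand from adenosine receptor A1 (Homo sapiens), read by scintillation counting, with a stated time of 60 min, tested at 1 uM; a lower number here means less inhibition, a higher number more inhibition at the concentration tested (going by the name of the read-out). Compound 3, carrying an amino group there, gives the lowest of the three numbers: the step of a number 13 percentage points lower from compound 1 to compound 3 (beyond the scatter) is beyond the scatter, while the step of a number 4 percentage points lower from compound 2 to compound 3 (within the scatter) is within it, as is a number 9 percentage points lower from compound 1 to compound 2 (within the scatter). The read-out for compound 3 is therefore the low point of this small set, though it is separated from compound 2 by no more than chance.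

Compound 4 `CCNC(=O)C1=C(C)NC(=O)NC1c1ccsc1` is the next step. It differs from compound 3 in a single place: ethyl in place of hydrogen on an amide-type nitrogen. For the measured compounds named here, none of the measured steps changes this amide-type nitrogen, so the nearest guidance is indirect: the steps of a number 13 percentage points lower from compound 1 to compound 3 (beyond the scatter) and a number 4 percentage points lower from compound 2 to compound 3 (within the scatter) show that a bulkier group on the carbonyl carbon gave equal or slightly higher numbers than the bare amino group. On that basis a small rise is expected, though one that may not exceed the scatter, so for compound 4 the expected step is a number 4 percentage points higher from compound 3 to compound 4 (within the scatter). In this assay compound 4 is expected to give 6%, with a likely range from 0% to 16%.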

Compound 4, a percentage reported as inhibition, at one concentration (the size of the read-out at that concentration, not a potency): 3%
Compound 4: middle estimate off by 3 percentage points, on the high side; the range from low to high includes it.
By their numbers in this assay, from the lowest: compounds 3, 4, 2 and 1 (each within the scatter of the next, the first and the last beyond it).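

This is the first change shown on the amide-type nitrogen itself, and in this assay ethyl in place of hydrogen gives a number 1 percentage points higher from compound 3 to compound 4 (within the scatter) and so leaves the read-out where it was, with both compounds close to the bottom of the scale, where a further loss could hardly show. Seen as a change on the carbonyl carbon, the ethylamino group gives a number 3 percentage points lower from compound 2 to compound 4 (within the scatter) and also a number 12 percentage points lower from compound 1 to compound 4 (beyond the scatter) and thus behaves like the bare amino group of compound 3. Among these compounds only tert-butoxy stands modestly clear of the two amides, while the propyl of compound 2 lies within the scatter of every other compound, so no clean split between amides and the rest can be drawn. Nothing in the data explains these small differences.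

On these data alone, what remains open is whether a longer chain such as butyl, or a benzyl group, on this nitrogen would lift the number in this assay clear of the scatter. Also open, as far as these compounds go, is whether a smaller ester group on the carbonyl carbon, such as methoxy or ethoxy, would keep the modest edge of compound 1.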